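Aryl substituent change from compound 2 to compound 3

A few compounds are considered here, and "the series" means these few. Any claim that something is new, unique, unknown or untested is made for them only; others in the source may bear on it.

Measured compounds:
compound 1 `CCCCN(CC)c1nc(C)nc2c1nnn2-c1ccc(C(C)C)cc1Br` — 7.5 nM
compound 2 `CCCCN(CC)c1nc(C)nc2c1nnn2-c1ccc(Br)cc1Br` — 20.4 nM

In an in vitro assay on 293-EBNA cells for binding affinity to corticotropin-releasing factor receptor 1 (Homo sapiens) (a lower number here means a stronger inhibitor, a higher number a weaker inhibitor), compound 2 gives 20.4 nM, the higher of the measured numbers; compound 1 gives 7.5 nM. Compound 3 `CCCCN(CC)c1nc(C)nc2c1nnn2-c1ccc(SC)cc1Br` differs from compound 2 by methylsulfanyl in place of bromo on an aromatic carbon. Among the compounds with values here, the only measured step that bears on this position is a 2.7-fold higher number from compound 1 to compound 2 (0.43 log units; beyond the scatter), in which the same bromo entered in place of isopropyl and the number rose. Within the data shown here, the present change removes that bromo again and puts in a carbon-containing group, as isopropyl is, so the step is expected to run the other way, though no measured step covers methylsulfanyl itself and the size is uncertain. For compound 3 a modest lower number is expected, a 1.7-fold lower number from compound 2 to compound 3 (0.23 log units; within the scatter). The estimate for compound 3 in this assay is 12 nM, with a range from 5 nM to 35 nM.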

Compound 3, inhibition constant: 10.6 nM
The estimate for compound 3 lay 1.1-fold (0.05 log units) above the measured number; measured number inside the range.
By their numbers in this assay, from the lowest: compounds 1, 3 and 2 (each within the scatter of the next, the first and the last beyond it).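

In this assay, methylsulfanyl on the aromatic carbon para to a large group gives a 1.9-fold lower number from compound 2 to compound 3 (0.28 log units; within the scatter) and, against isopropyl at the same place, a 1.4-fold higher number from compound 1 to compound 3 (0.15 log units; within the scatter). Methylsulfanyl therefore cannot be separated from either bromo or isopropyl, although those two groups are separated from each other beyond the scatter. This place accepts a sulfur-linked group that brings a hydrogen-bond acceptor with no change beyond the scatter, but nothing at hand accounts for this reading.

Open, as far as these compounds go, is how methoxy, methylsulfonyl or a dimethylamino group would read at this place in this assay. From the compounds shown here alone, all three compounds also keep the bromo group meta to this place and the shared core fixed, so whether the reading holds with a chlorine or a methyl group in place of that bromo remains untested in these data.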